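Ring substituent change on a triazole with no measured potency

The source may hold more compounds than are shown below. What is called first, only, known or untested is meant among the compounds shown, and "the series" means these compounds.

Compounds measured in an ADME assay on L02 cells (Homo sapiens) for antiproliferative activity, read by MTT assay, with a stated time of 48 h (on this read-out lower numbers stand for stronger inhibition and higher numbers for weaker inhibition), so far:
compound 1 `N#CC1=C(N)Oc2c(c3nc4ccccc4nc3c3ccccc23)C12C(=O)N(Cc1cnnn1-c1ccccc1Br)c1ccccc12`: > 50000 nM
compound 2 `COc1ccc(-n2nncc2CN2C(=O)C3(C(C#N)=C(N)Oc4c3c3nc5ccccc5nc3c3ccccc43)c3ccccc32)cc1`: > 50000 nM
compound 3 `N#CC1=C(N)Oc2c(N)cc3nc4ccccc4nc3c2C12C(=O)N(Cc1cnnn1-c1cccc(Br)c1)c1ccccc12`: > 50000 nM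

Each of these values is a limit of this assay, not a number: the compounds did not reach half-maximal inhibition within the tested range. Compound 3 therefore stands at the limit, and so do the other two, as the limit of > 50000 nM in this assay, at which 3 of the 3 values shown sit, states. Within the data shown here, the only step between measured compounds is a step that the two limits leave unreadable from compound 1 to compound 2, which the two limits leave unreadable.

Compound 4 `CCc1cccc(CC)c1-n1nncc1CN1C(=O)C2(C(C#N)=C(N)Oc3c(N)cc4nc5ccccc5nc4c32)c2ccccc21` is not yet measured. It differs from compound 3 by 2,6-diethylphenyl in place of 3-bromophenyl on an aromatic nitrogen. Among the measured compounds shown here, no measured step bears on this change; the one comparable change on the same aromatic nitrogen could not be sized. Since compound 3 and all other measured compounds sit at the limit, a step of a number no higher from compound 3 to compound 4 (the limit leaves the size open) is expected, with compound 4 most likely again reported only as a limit. The estimate for compound 4 in this assay is 50000 nM, within 20000 nM to 200000 nM.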

Compound 4, half-maximal inhibitory concentration: > 50000 nM
Compound 4: a limit, no number; the forecaster's own chance of this, stated with the estimate: 85%; the middle value sits exactly at the limit.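

Compound 4 gives only a limit, as compound 3 does, so the change from compound 3 to compound 4 cannot be read as a step of any size: the limit of > 50000 nM in this assay, at which 4 of the 4 values shown sit.

The compounds shown leave open whether any group on this aromatic nitrogen would give a real number in this assay, and how large the effect of such a change would be.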